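Trifluoromethyl for chloro on compound 1

A few compounds are considered here, and "the series" means these few. Any claim that something is new, unique, unknown or untested is made for them only; others in the source may bear on it.

Within the data shown here, in a physicochemical assay for solubility (a lower number here means a less soluble compound, a higher number a more soluble compound), compound 1 (`O=C(Nc1ccccc1Cl)c1cc(Cl)ccc1O`) gives 5 ug/mL, the highest of the two numbers measured so far. Compound 2 (`O=C(Nc1ccc(F)cc1Cl)c1cc(Cl)ccc1O`) gives 1.2 ug/mL. Compound 3 (`O=C(Nc1ccc(C(F)(F)F)cc1Cl)c1cc(Cl)ccc1O`) reads < 1 ug/mL, which is a limit and not a number.

Compound 4 (`O=C(Nc1ccccc1C(F)(F)F)c1cc(Cl)ccc1O`) has not yet been measured. It differs from compound 1 by one exchange: trifluoromethyl in place of chloro on an aromatic carbon. This puts trifluoromethyl in place of chloro on an aromatic carbon, ortho to a large group.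

Among the measured compounds shown here, no measured step makes this exact exchange, and none removes chloro from that place. The closest evidence is trifluoromethyl in place of hydrogen, which gave an at least 5.0-fold lower number from compound 1 to compound 3 (0.69 log units; beyond the scatter), and fluoro in place of hydrogen, which gave a 4.2-fold lower number from compound 1 to compound 2 (0.62 log units; beyond the scatter). Trifluoromethyl in place of fluoro gave an at least 1.2-fold lower number from compound 2 to compound 3 (0.07 log units; that floor lies within the scatter), so that comparison separates the two groups no further. The two steps that start at compound 1 both run toward a lower number, and the same direction is expected here. A smaller size is expected, as a halogen-bearing group is replaced rather than added to hydrogen. The expected change is a 2.3-fold lower number from compound 1 to compound 4 (0.36 log units; beyond the scatter), a small step toward a lower number. Compound 4 is estimated at 2.2 ug/mL, with an expected range from 1 ug/mL to 6 ug/mL.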

Compound 4, solubility: > 47 ug/mL
Compound 4 was reported as a limit; the forecaster's own chance of this, stated with the estimate: 20%; at least 21-fold (1.32 log units) between middle value and limit.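

In this assay, trifluoromethyl in place of chloro on an aromatic carbon, ortho to a large group, gave an at least 9.4-fold higher number from compound 1 to compound 4 (0.97 log units; beyond the scatter). This runs against the two earlier steps that start at compound 1, so the direction seen when a group replaced hydrogen did not carry over to this exchange at this position: trifluoromethyl in place of hydrogen had given an at least 5.0-fold lower number from compound 1 to compound 3 (0.69 log units; beyond the scatter), and the same group now stands with a rise rather than a fall. The reading of compound 4 is a limit and not a number: the limit of > 47 ug/mL in this assay, at which 1 of the 4 values shown sits.

The compounds shown leave open whether the rise goes with the loss of chloro or with the entry of trifluoromethyl, and what an amine, a carboxylic acid or a longer chain at this position would give in this assay. They also leave open whether the exchange would give a rise of this kind in compound 2 or compound 3, which carry a second change on the same ring, and how far the reading of compound 4 extends beyond its limit.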